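Aryl swap on the chalcone arm of the series

A few compounds are considered here, and "the series" means these few. Any claim that something is new, unique, unknown or untested is made for them only; others in the source may bear on it.

Compound 1 `COc1ccc(/C=C/C(=O)c2ccc(NC(=O)CN3CCN(c4cc5c(cc4F)c(=O)c(C(=O)O)cn5C4CC4)CC3)cc2)cc1OC` gives 2.5% in an assay on isolated protein for inhibition of DNA topoisomerase 1 (Homo sapiens), with a stated time of 30 min, tested at 20 uM; a higher number here means a stronger effect of the compound at the concentration tested, a lower number a weaker effect. Compound 2 `COc1cc(/C=C/C(=O)c2ccc(NC(=O)CN3CCN(c4cc5c(cc4F)c(=O)c(C(=O)O)cn5C4CC4)CC3)cc2)cc(OC)c1OC` gives 11.5% in this assay, and the step of a number 9 percentage points higher from compound 1 to compound 2 (within the scatter) lies within the scatter. Among the measured compounds shown here, on the two numbers so far, compound 2 is the one with the larger read-out, with compound 1 nearest, but since that step is within the scatter no order between the two is established; both read-outs are small.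

Compound 3 `Cc1ccc(/C=C/C(=O)c2ccc(NC(=O)CN3CCN(c4cc5c(cc4F)c(=O)c(C(=O)O)cn5C4CC4)CC3)cc2)c(C)c1` is not yet measured. It differs from compound 2 by 2,4-dimethylphenyl in place of 3,4,5-trimethoxyphenyl on a double-bonded chain carbon bound to a double-bonded chain carbon. For the measured compounds named here, the only measured step, a number 9 percentage points higher from compound 1 to compound 2 (within the scatter), concerns a methoxy in place of hydrogen on an aromatic carbon and so touches the same aryl group, but it is of a different kind and did not move the read-out beyond the scatter. No measured step removes all three methoxy groups or brings in a 2,4-dimethylphenyl, so there is no shown basis for a step beyond the scatter.

Compound 3 is therefore expected to give about 7%, in the range -5% to 20%, in this assay, which means an expected step of a number 4.5 percentage points lower from compound 2 to compound 3 (within the scatter).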

Compound 3, a percentage reported as inhibition, at one concentration (the size of the read-out at that concentration, not a potency): 11%
Beside the measured number, compound 3's estimate is 4 percentage points below it; low and high end bracket the measured number.
By their numbers in this assay, from the lowest: compounds 1, 3 and 2 (each within the scatter of the next).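

In this assay, 2,4-dimethylphenyl in place of 3,4,5-trimethoxyphenyl on a double-bonded chain carbon bound to a double-bonded chain carbon gives a number 0.5 percentage points lower from compound 2 to compound 3 (within the scatter), so this position tolerates the removal of every methoxy group, and of all the hydrogen-bond acceptors on this aryl group, without a step beyond the scatter. The comparison with the 3,4-dimethoxyphenyl group reads the same, at a number 8.5 percentage points higher from compound 1 to compound 3 (within the scatter), so the three aryl groups, with 8 or 12 heavy atoms in the two counted here, fall into no established order and no substituent pattern at this position can yet be tied to the read-out. Nothing measured alongside these read-outs offers an explanation for this flat result.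

Still open, from the compounds shown here alone, is whether an aryl group carrying a primary amine or a hydroxyl, or a chain such as a longer alkyl group at this place, would give a step beyond the scatter in this assay. These are read-outs at a single concentration, so they leave open any difference in potency among the three compounds and any effect of changes elsewhere on the shared core.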